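Tert-butyl to fluoro: working notes on compound 4

The source may report more compounds than this note shows. Statements on the series, on what has been measured and on what is new or still open speak of the compounds shown alone.

Of the compounds shown here, three have numbers so far in a physicochemical assay for lipophilicity, at pH 7.4 (on this read-out higher numbers stand for higher lipophilicity and lower numbers for lower lipophilicity), and they span a wide range. Compound 1 (`CCc1ccc(N(CC(C)C)S(=O)(=O)c2ccc3c(c2)C(F)CC(C2CCOCC2)O3)cc1`) reads 5.02 in this set. Compound 2 (`CC(C)CN(c1ccc(C(C)(C)C)cc1)S(=O)(=O)c1ccc2c(c1)C(=O)CC(C1CCOCC1)O2`) reads 4.97 and stands level with compound 1 within the scatter, at the high end of the three numbers. Compound 3 (`CCS(=O)(=O)c1ccc(CNS(=O)(=O)c2ccc3c(c2)C(=O)CC(C2CCOCC2)O3)nc1`) lies far lower at 0.32 and its gap to compound 2 is beyond the scatter.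

Compound 4 (`CC(C)CN(c1ccc(F)cc1)S(=O)(=O)c1ccc2c(c1)C(=O)CC(C1CCOCC1)O2`) has no number yet. It differs from compound 2 in one place: fluoro in place of tert-butyl on an aromatic carbon (fluoro in place of tert-butyl on an aromatic carbon, para to a large group). Among the measured compounds shown here, no two measured compounds differ in only one place, so the series offers no direct step for comparison, and the expected size rests on the structural change alone. In this assay compound 4 is expected to fall clearly from the level of compound 2 at 4.97 and still stay well above compound 3 at 0.32 in this series. The estimated change is a number 1.27 log units lower from compound 2 to compound 4 (beyond the scatter) downward, beyond the scatter. Compound 4 is estimated at 3.7 with an expected range from 3.2 to 4.2 on this read-out.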

Compound 4, distribution coefficient: 3.48
Beside the measured number, compound 4's estimate is 0.22 log units above it; measured number inside the range.
By their numbers in this assay, from the lowest: compound 3; then compound 4; then compounds 2 and 1 (each within the scatter of the next).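

In this assay, among the compounds shown here, the change from 4-(tert-butyl)phenyl to 4-fluorophenyl gives the first step that can be read at a single place: a number 1.49 log units lower from compound 2 to compound 4 (beyond the scatter). This shows that the read-out responds to the group on this aromatic carbon, para to a large group, when the rest of the structure stays the same. The step comes with tert-butyl, 4 heavy atoms, leaving and fluoro, 1 heavy atom, entering, with neither group carrying hydrogen-bond donors, hydrogen-bond acceptors or a net charge, but nothing available accounts for its size.

From the compounds shown here alone, with one pair to read, it remains open whether the size of this step follows the number of heavy atoms in the group or depends on the identity of the group, and a methyl, a methoxy or a chloro at this place would help to separate the two. An amine or a carboxylic acid at the same place, each of which would bring in a type of group absent from this pair, also remains an open case on this read-out.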